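Furan-3-yl in place of 2-fluorobenzyl on the indazole nitrogen

This account rests on a few compounds, and the source may have more. Where it says the series, first, only, none or still open, it means among the compounds named here.

Compound 1 `CCOC(=O)c1ccc(-c2nn(Cc3cccc(Cl)c3)c3ccccc23)cc1`: > 10000 nM in a functional assay on cells (Platelet, Homo sapiens) for inhibition (on this read-out lower numbers stand for stronger inhibition and higher numbers for weaker inhibition), a limit of the assay.
Compound 2 `CCOC(=O)c1ccc(-c2nn(Cc3ccc(Cl)cc3)c3ccccc23)cc1`: > 10000 nM, a limit of the assay.
Compound 3 `CCOC(=O)c1ccc(-c2nn(Cc3ccccc3F)c3ccccc23)cc1`: > 10000 nM, a limit of the assay.

Compound 3 therefore stands only at the limit, together with the other two values shown, as the limit of > 10000 nM in this assay, at which 3 of the 3 values shown sit, states. Compound 4 `CCOC(=O)c1ccc(-c2nn(-c3ccoc3)c3ccccc23)cc1` differs from compound 3 in one place: furan-3-yl in place of 2-fluorobenzyl on an aromatic nitrogen. The steps measured so far, a step that the two limits leave unreadable from compound 1 to compound 3, a step that the two limits leave unreadable from compound 2 to compound 3 and a step that the two limits leave unreadable from compound 1 to compound 2, all remain unreadable, so none of them gives a readable size for a change at this nitrogen. The expected step for compound 4 is a step that the limit leaves unreadable from compound 3 to compound 4, with a limit again the most likely outcome. Compound 4 is estimated at 15000 nM, within 3000 nM to 60000 nM.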

Compound 4, half-maximal inhibitory concentration: > 10000 nM
Compound 4 gave a limit, no number; the forecaster's own chance of this, stated with the estimate: 75%; the middle value does not contradict the limit.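

Compound 4 gave only a limit, as did compound 1, compound 2 and compound 3, so none of the steps between them can be read: the limit of > 10000 nM in this assay, at which 4 of the 4 values shown sit.

The compounds shown leave open how far any of these groups on the aromatic nitrogen changes inhibition in this assay.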